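Swapping the aryl on the triazole nitrogen of a weaker analogue

The source may hold more compounds than are shown below. What is called first, only, known or untested is meant among the compounds shown, and "the series" means these compounds.

Measured compounds:
Compound 1, `COc1cc2c(Oc3ccc(NC(=O)c4cn(-c5ccc(F)c(F)c5)nn4)cc3F)ccnc2cc1OCCCN1CCCCC1`: in a functional assay on NCI-H460 cells (Homo sapiens) for cytotoxicity, read by MTT assay, with a stated time of 72 h (a higher number here means a weaker inhibitor, a lower number a stronger inhibitor), compound 1 gives 250 nM.
Compound 2, `COc1cc2c(Oc3ccc(NC(=O)c4cn(-c5ccccc5C)nn4)cc3F)ccnc2cc1OCCCN1CCC(C)CC1`: in this assay compound 2 gives 2730 nM.

Going by the values given here, compound 2 stands at the higher of the two numbers measured so far, and its nearest neighbour is compound 1, which sits clearly lower, beyond the usual scatter. The two differ in two places at once, so the numbers alone do not say which of the two changes carries the gap.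

Compound 3, `COc1cc2c(Oc3ccc(NC(=O)c4cn(-c5ccc(F)c(F)c5)nn4)cc3F)ccnc2cc1OCCCN1CCC(C)CC1`, is not yet measured. It keeps the ring-bearing chain of compound 2 and differs from it only in one place: 3,4-difluorophenyl in place of 2-methylphenyl on an aromatic nitrogen. With this change compound 3 shares its triazole substituent with compound 1 and its chain with compound 2.

Among the compounds with values here, no step between two measured compounds isolates this change. The expected step in this assay is toward a lower number and beyond the scatter, as a 6.1-fold lower number from compound 2 to compound 3 (0.78 log units; beyond the scatter), because compound 1 gives 250 nM with the same aryl. Compound 3 is therefore estimated at 450 nM, within a range of 150 nM to 1400 nM.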

Compound 3, half-maximal inhibitory concentration: 260 nM
Compound 3: middle estimate off by 1.7-fold (0.24 log units), on the high side, and the stated range covers the measured number.
By their numbers in this assay, from the lowest: compounds 1 and 3 (each within the scatter of the next); then compound 2.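

Exchanging 2-methylphenyl for 3,4-difluorophenyl on an aromatic nitrogen of the five-membered aromatic ring with 3 nitrogen can now be read as a single change, and in this assay it gives an 11-fold lower number from compound 2 to compound 3 (1.02 log units; beyond the scatter), a large step. Going by these compounds alone, the other single change, methyl in place of hydrogen on a saturated ring carbon, gives a 1.0-fold higher number from compound 1 to compound 3 (0.02 log units; within the scatter), so of the two changes that the earlier compounds left tangled, only the aryl exchange shows a step beyond the scatter. Nothing measured on these compounds gives a reason for the size of this step.

The compounds shown leave open how much of the step follows the departure of the methyl and how much the arrival of the fluorines, a question that an unsubstituted phenyl or a 3-fluorophenyl on the same nitrogen would help to separate. They also leave open whether the methyl on the saturated ring would be as silent alongside 2-methylphenyl, and how a morpholine in place of that saturated ring would read in this assay.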